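This account rests on a few compounds, and the source may have more. Where it says the series, first, only, none or still open, it means among the compounds named here.

Measured compounds in a functional assay on AN3-CA cells (Homo sapiens) for antiproliferative activity, read by MTT assay, with a stated time of 72 h; on this read-out higher numbers stand for weaker inhibition and lower numbers for stronger inhibition:
- compound 1 `O=C(Nc1ccc(Cl)c(-c2nnc3c(Cl)cccn23)c1)c1ccc(F)cc1Cl`: compound 1 gives > 100000 nM, which is a limit of the assay and not a number.
- compound 2 `Cc1nc(C(=O)Nc2ccc(Cl)c(-c3nnc4c(Cl)cccn34)c2)cs1`: compound 2 gives > 100000 nM, again only a limit.
- compound 3 `O=C(Nc1ccc(Cl)c(-c2nnc3c(Cl)cccn23)c1)c1ccon1`: compound 3 gives > 100000 nM, again only a limit.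

Compound 1 therefore stands nowhere on a scale of numbers in this assay; only a limit is known for it, and the same holds for the two other measured compounds, as the limit of > 100000 nM in this assay, at which 3 of the 3 values shown sit, records. The three measured steps, which all exchange the group on the carbonyl carbon, are a step that the two limits leave unreadable from compound 1 to compound 2, a step that the two limits leave unreadable from compound 1 to compound 3 and a step that the two limits leave unreadable from compound 2 to compound 3; none of them can be read, so no effect of any change at this position is visible.

Compound 4 `O=C(Nc1ccc(Cl)c(-c2nnc3c(Cl)cccn23)c1)c1c(F)cccc1Cl` is the next compound in this series and differs from compound 1 by 2-chloro-6-fluorophenyl in place of 2-chloro-4-fluorophenyl on a carbonyl carbon. Going by the values given here, the steps that bear on it are the three unreadable exchanges at the carbonyl carbon; each of them left the compound at the limit. The expectation for a step that the limit leaves unreadable from compound 1 to compound 4 is accordingly no readable step, with compound 4 most probably again reported only as a limit. The estimate for compound 4 in this assay is 150000 nM, with a range from 40000 nM to 600000 nM.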

Compound 4, half-maximal inhibitory concentration: > 100000 nM
Compound 4: a limit, no number; the forecaster's own chance of this, stated with the estimate: 80%; the middle value does not contradict the limit.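

In this assay compound 4 gives > 100000 nM, which is a limit and not a number. No new step can be read from compound 1, compound 2 or compound 3 to compound 4, and all four compounds stay at one limit: the limit of > 100000 nM in this assay, at which 4 of the 4 values shown sit.

The compounds shown leave open whether exchanging the group on the carbonyl carbon changes the result in this assay at all.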